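This account rests on a few compounds, and the source may have more. Where it says the series, first, only, none or still open, it means among the compounds named here.

Within the data shown here, in an ADME assay on J774 cells (Mus musculus) for cytotoxicity, read by fluorescence and resazurin assay, with a stated time of 24 h (on this read-out higher numbers stand for lower toxicity in this test and lower numbers for higher toxicity in this test), compound 3 `O=S(=O)(Nc1ccc2nccnc2c1)c1ccc(Cl)cc1` gives 23800 nM, the lowest number among the compounds measured so far. Compound 1 `O=S(=O)(Nc1cccc2cnccc12)c1ccc(Cl)cc1`, which has a different core, gives 60800 nM, a higher number than compound 3. Compound 2 `O=[N+]([O-])c1ccc(S(=O)(=O)Nc2ccc3nccnc3c2)cc1` gives only a limit, >= 300000 nM.

Compound 4 `O=S(=O)(Nc1ccc2nccnc2c1)c1ccc(F)cc1` keeps the core of compound 3 and replaces chloro with fluoro on an aromatic carbon, para to a large group (fluoro in place of chloro on an aromatic carbon). Among the measured compounds shown here, only one measured step bears on this change: an at least 12-fold lower number from compound 2 to compound 3 (1.10 log units; beyond the scatter), with chloro in place of nitro on an aromatic carbon. That large step shows that the number in this assay can respond strongly to a change of group in this series, but it rests on a single pair and starts from a limit. It does not involve fluoro, so it gives no direct measure of the new change. No step beyond the usual scatter is therefore expected, although the low standing of compound 3 at 23800 nM tilts the estimate slightly towards a higher number. The expected change is a 1.5-fold higher number from compound 3 to compound 4 (0.17 log units; within the scatter). For compound 4 the estimated value is 35000 nM, with an expected range from 13000 nM to 100000 nM.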

Compound 4, half-maximal cytotoxic concentration: 43900 nM
Compound 4: middle estimate off by 1.3-fold (0.10 log units), on the low side; low and high end bracket the measured number.
By their numbers in this assay, from the lowest: compounds 3, 4 and 1 (each within the scatter of the next, the first and the last beyond it). At a limit, above all of these: compound 2.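

In this assay, among these compounds, a 1.8-fold higher number from compound 3 to compound 4 (0.27 log units; within the scatter), so on this aromatic carbon, para to a large group, the read-out does not separate fluoro from chloro, a comparison that the earlier compounds could not offer. Replacing nitro with fluoro gives a step beyond the scatter, an at least 6.8-fold lower number from compound 2 to compound 4 (0.83 log units; beyond the scatter), which runs in the same direction as an at least 12-fold lower number from compound 2 to compound 3 (1.10 log units; beyond the scatter), so the drop seen earlier is not particular to chloro but holds for both halogens shown. Compound 2 gives a limit of the assay and not a number, so the full size of both steps from it stays unknown: the limit of >= 300000 nM in this assay, at which 1 of the 4 values shown sits.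

The compounds shown leave open how an amine, a methoxy group or a carboxylic acid at this position would read in this assay, and whether any group other than nitro would stand far from chloro and fluoro. They also leave open whether the change from 4-chlorophenyl to 4-fluorophenyl would read the same way on the core of compound 1, where only the chloro compound appears.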